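Compound 1 to compound 3: a new group on the carbonyl

The source may hold more compounds than are shown below. What is called first, only, known or untested is meant among the compounds shown, and "the series" means these compounds.

Compound 1 (`COc1cc(-c2nn(-c3cccc(NC(=O)c4cccc(C(F)(F)F)c4)c3)cc2-c2ccncc2)ccc1Cl`) is read in a functional assay on UACC-62 cells (Homo sapiens) for inhibition, read by sulforhodamine B assay, with a stated time of 48 h (a lower number here means a stronger inhibitor of growth, a higher number a weaker inhibitor of growth), as the reference point here. Compound 1 gives > 50000 nM as its reading, which is a limit of the assay and not a number. Compound 2 (`O=C(Nc1cccc(-n2cc(-c3ccncc3)c(-c3ccc(Cl)c(O)c3)n2)c1)Nc1cc(C(F)(F)F)cc(C(F)(F)F)c1`) gives 2190 nM as a true number in this assay and so shows that the series can reach a measured value. Compound 3 (`COc1cc(-c2nn(-c3cccc(NC(=O)Nc4ccc(Cl)c(C(F)(F)F)c4)c3)cc2-c2ccncc2)ccc1Cl`) keeps the core of compound 1 and carries (4-chloro-3-(trifluoromethyl)phenyl)amino in place of 3-(trifluoromethyl)phenyl on a carbonyl carbon. Among the measured compounds shown here, no measured step bears on this change, so the expectation is loose. A move toward stronger inhibition of growth, beyond the scatter, is expected, though a reading at the limit remains possible. The estimated change is an at least 8.3-fold lower number from compound 1 to compound 3 (0.92 log units; beyond the scatter) in this assay for this single replacement. For compound 3 the expected value is 6000 nM within an estimated range of 1500 nM to 30000 nM for total growth inhibition.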

Compound 3, concentration for total growth inhibition: 2090 nM
Compound 3: middle estimate off by 2.9-fold (0.46 log units), on the high side; the range from low to high includes it.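

In this assay, among the compounds shown here, (4-chloro-3-(trifluoromethyl)phenyl)amino in place of 3-(trifluoromethyl)phenyl on a carbonyl carbon gives an at least 23-fold lower number from compound 1 to compound 3 (1.37 log units; beyond the scatter) and provides the first readable step. At this position, a single replacement on the core of compound 1 yields a true number: compound 3 gives 2090 nM in this assay. The step is a minimum and not a full size, since the value of compound 1 is a limit of the assay and not a number: the limit of > 50000 nM in this assay, at which 1 of the 3 values shown sits.

The replacement brings in the amino nitrogen and the chlorine together, so this step cannot assign the change to either one. The compounds shown also leave open how a saturated amine such as piperidine would read in place of this aryl amino group on the carbonyl carbon.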